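The source may report more compounds than this note shows. Statements on the series, on what has been measured and on what is new or still open speak of the compounds shown alone.

In a functional assay on the whole organism with Mus musculus as the target, with a stated time of 0.5 h (a lower number here means that less compound is needed, a higher number that more compound is needed for the effect), compound 3 `CC[C@@]1(c2ccccc2)OC(=O)NC1=O` gives 42 mg/kg, which lies within the scatter of compound 1 `CC[C@]1(c2ccccc2)OC(=O)N(C)C1=O` at 69 mg/kg and of compound 2 `CCC1(c2ccccc2)OC(=O)N(C)C1=O` at 45 mg/kg. Compound 4 `CC[C@@]1(c2ccccc2)OC(=O)N(C)C1=O` has methyl in place of hydrogen on an amide-type nitrogen in a ring. Compounds 1 and 2 already carry this methyl, yet neither value stands beyond the scatter from compound 3. Among the compounds with values here, the only measured step, a 1.5-fold lower number from compound 1 to compound 2 (0.19 log units; within the scatter), reflects a difference in drawn configuration the fact that one of compounds 1 and 2 is drawn with a defined configuration and the other without, at the place where they differ and does not test the methyl directly. No shift beyond the scatter is therefore expected in this assay. The expected step is a 1.1-fold higher number from compound 3 to compound 4 (0.03 log units; within the scatter). For compound 4 the estimated dose is 45 mg/kg, with an expected range of 24 mg/kg to 85 mg/kg.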

Compound 4, dose for half-maximal effect: 64 mg/kg
The estimate for compound 4 lay 1.4-fold (0.15 log units) below the measured number, within the range that was stated.
By their numbers in this assay, from the lowest: compounds 3, 2, 4 and 1 (each within the scatter of the next).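

Methyl in place of hydrogen on the amide-type nitrogen in a ring now has a direct test in this assay, and the result, a 1.5-fold higher number from compound 3 to compound 4 (0.18 log units; within the scatter), shows no shift beyond the scatter. Configuration at the saturated ring carbon also makes no clear difference, with a 1.1-fold lower number from compound 1 to compound 4 (0.03 log units; within the scatter): the fact that compounds 1 and 4 differ only in the configuration as drawn. The same holds for a 1.4-fold higher number from compound 2 to compound 4 (0.15 log units; within the scatter): the fact that one of compounds 2 and 4 is drawn with a defined configuration and the other without, at the place where they differ.

Only hydrogen and methyl are shown on this nitrogen. Going by these compounds, whether a longer chain such as propyl, or a benzyl group, would move the dose beyond the scatter remains open.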